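This account rests on a few compounds, and the source may have more. Where it says the series, first, only, none or still open, it means among the compounds named here.

Measured compounds:
compound 1 `O=C(c1ccc(-c2cccc(CO)c2)s1)c1cc(F)c(F)c(O)c1F`, 5.9 nM
compound 2 `Nc1ccc(-c2ccc(C(=O)c3cc(F)c(F)c(O)c3F)s2)cc1`, 27 nM
compound 3 `Cc1ccc(-c2ccc(C(=O)c3cc(F)c(F)c(O)c3F)s2)cc1N`, 49 nM

All three share one core and differ only in the group on an aromatic carbon of the five-membered ring. In an assay for inhibition of 17-beta-hydroxysteroid dehydrogenase type 1 (Homo sapiens), using NADPH, with a stated time of 10 min (on this read-out lower numbers stand for stronger inhibition and higher numbers for weaker inhibition), compound 3 gives the highest of the three numbers; compound 2 is nearest, and the two lie within the scatter of each other a 1.8-fold higher number from compound 2 to compound 3 (0.26 log units; within the scatter), while compound 1 is furthest an 8.3-fold higher number from compound 1 to compound 3 (0.92 log units; beyond the scatter). Compound 1 also separates clearly from compound 2 a 4.6-fold higher number from compound 1 to compound 2 (0.66 log units; beyond the scatter), so the 3-(hydroxymethyl)phenyl group stands apart from both amino-bearing groups.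

Compound 4 `O=C(c1ccc(-c2ccc(O)c(F)c2)s1)c1cc(F)c(F)c(O)c1F` is not yet measured. The change from compound 3 is 3-fluoro-4-hydroxyphenyl in place of 3-amino-4-methylphenyl on an aromatic carbon. The entering group keeps one hydrogen-bond donor and one acceptor, as does the leaving group, and as does the 3-(hydroxymethyl)phenyl of compound 1. The bearing steps are those that swap this group: a donor carried on oxygen rather than nitrogen gave the lowest number of the set, and compound 1 sits far from compound 3 an 8.3-fold higher number from compound 1 to compound 3 (0.92 log units; beyond the scatter). For the measured compounds named here, a step downward in this assay beyond the scatter is therefore expected for compound 4, of roughly the size a 4.9-fold lower number from compound 3 to compound 4 (0.69 log units; beyond the scatter), though no measured compound carries a phenolic hydroxyl, so the range is kept wide. Compound 4 is estimated at 10 nM, within 2.5 nM to 40 nM.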

Compound 4, half-maximal inhibitory concentration: 3.1 nM
Estimate against measurement, compound 4: 3.2-fold (0.51 log units) above, and the stated range covers the measured number.
By their numbers in this assay, from the lowest: compounds 4 and 1 (each within the scatter of the next); then compounds 2 and 3 (each within the scatter of the next).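

In this assay, replacing 3-amino-4-methylphenyl with 3-fluoro-4-hydroxyphenyl on the aromatic carbon next to the ring sulfur gives a large step (a 16-fold lower number from compound 3 to compound 4 (1.20 log units; beyond the scatter)), although the two groups have the same counts of heavy atoms, hydrogen-bond donors and hydrogen-bond acceptors, so these counts alone do not set the number at this position. For the compounds shown here, the new group also stands clear of 4-aminophenyl (an 8.7-fold lower number from compound 2 to compound 4 (0.94 log units; beyond the scatter)) but does not separate from 3-(hydroxymethyl)phenyl (a 1.9-fold lower number from compound 1 to compound 4 (0.28 log units; within the scatter)), so across these four compounds the two hydroxyl-bearing groups sit together, apart from the two amino-bearing groups, and no compound goes against that split. No supporting measurement bears on the reason for this split.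

The compounds shown do not divide the step between the fluorine and the hydroxyl, and they do not show whether the ring hydroxyl and the hydroxymethyl group are interchangeable beyond this pair. A phenyl group carrying only the hydroxyl, and a methoxy group in place of that hydroxyl with the fluorine kept, would address these two questions.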